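Amide variation at the aminopyridine of the shared core

A few compounds are considered here, and "the series" means these few. Any claim that something is new, unique, unknown or untested is made for them only; others in the source may bear on it.

Measured so far in a functional assay on HT-29 cells (Homo sapiens) for antiproliferative activity, read by MTT assay, with a stated time of 72 h, tested at 10 uM; on this read-out lower numbers stand for less inhibition and higher numbers for more inhibition at the one concentration tested (going by the name of the read-out):
compound 1 `CC(=O)Nc1cc(Oc2ccc(Nc3nccc4[nH]cc(-c5ccc(F)cc5)c(=O)c34)cc2F)ccn1` gives 36.8%
compound 2 `CC(C)C(=O)Nc1cc(Oc2ccc(Nc3nccc4[nH]cc(-c5ccc(F)cc5)c(=O)c34)cc2F)ccn1` gives 83.4%
compound 3 `CC(C)(O)Cn1cc(-c2ccc(F)cc2)c(=O)c2c(Nc3ccc(Oc4ccnc(NC(=O)C5CC5)c4)c(F)c3)nccc21` gives -2.6%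

Compound 2 stands highest of the three numbers in this assay. Among the measured compounds shown here, its nearest neighbour is compound 1, and the only single-point step among the measured compounds is the one between them: a number 46.6 percentage points higher from compound 1 to compound 2 (beyond the scatter). Compound 3 differs from compound 2 in more than one place, so its low number cannot be tied to any one change; its value and that of compound 2 merely show the widest spread of the set.

Compound 4 `O=C(CO)Nc1cc(Oc2ccc(Nc3nccc4[nH]cc(-c5ccc(F)cc5)c(=O)c34)cc2F)ccn1` is not yet measured. It differs from compound 2 as follows: hydroxymethyl in place of isopropyl on a carbonyl carbon. The isopropyl that leaves is the same group whose arrival accounted for the gain from compound 1 to compound 2, so that step bears directly on this one, in the reverse direction. Hydroxymethyl is not methyl, so compound 1 is only a rough comparator, but no measured compound supports keeping the full level of compound 2 without isopropyl. A fall beyond the scatter is therefore expected, a number 45.4 percentage points lower from compound 2 to compound 4 (beyond the scatter), landing near compound 1. The estimate for compound 4 in this assay is 38%, expected between 10% and 68%.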

Compound 4, a percentage reported as inhibition, at one concentration (the size of the read-out at that concentration, not a potency): 18.5%
Beside the measured number, compound 4's estimate is 19.5 percentage points above it, and the stated range covers the measured number.
By their numbers in this assay, from the lowest: compound 3; then compound 4; then compound 1; then compound 2.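

Three amide forms on the shared core can now be compared in this assay and the position remains highly sensitive: replacing isopropyl with hydroxymethyl gives a number 64.9 percentage points lower from compound 2 to compound 4 (beyond the scatter) and removes the level reached by compound 2. The second step isolates the hydroxy change, since hydroxy in place of hydrogen on the saturated chain carbon bound to the carbonyl carbon gives a number 18.3 percentage points lower from compound 1 to compound 4 (beyond the scatter) and the number falls beyond the scatter. Chain size alone therefore does not order compound 1, compound 2 and compound 4, as the hydroxymethyl amide gives the lowest number of the three even though it is not the smallest group. No supporting measurement is available to explain the effect of either change at this position.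

Left open is whether the fall belongs to the free hydroxy itself or would also appear with a methoxymethyl group, and whether an aminomethyl group or a longer alkyl chain on the carbonyl carbon would hold the level of compound 2. The cyclopropyl amide appears only in compound 3, which differs from compound 2 in more than one place, so its contribution at this position remains unresolved.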